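A few compounds are considered here, and "the series" means these few. Any claim that something is new, unique, unknown or untested is made for them only; others in the source may bear on it.

Measured so far:
compound 1, `Cc1ccc(NC(=O)Nc2ccccc2)cc1S(=O)(=O)N(C)C`, 1400 nM
compound 2, `Cc1ccc(NC(=O)Nc2ccccc2F)cc1S(=O)(=O)N(C)C`, 3900 nM

Among the compounds with values here, in an assay on HEK293 cells for activation of Kir3.1/Kir3.2 (Homo sapiens), read by fluorescence and thallium flux, with a stated time of 4 min (a lower number here means that less compound is needed, a higher number that more compound is needed for the effect), compound 1 holds the lower of the two numbers; compound 2 sits higher, the only comparison available being a 2.8-fold higher number from compound 1 to compound 2 (0.44 log units; beyond the scatter). That step is a fluoro in place of hydrogen on an aromatic carbon.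

Compound 3, `Cc1ccc(NC(=O)Nc2cccc(F)c2)cc1S(=O)(=O)N(C)C`, is not yet measured. It differs from compound 1 by fluoro in place of hydrogen on an aromatic carbon. Within the data shown here, the fluorine thus enters the same ring as in compound 2 but at a different position on it, so no measured step covers this change exactly. The step from compound 1 to compound 2 is the only one that bears on it, and it was modest. On that basis a similar, small rise from compound 1 to compound 3 is expected, possibly within the scatter: a 1.6-fold higher number from compound 1 to compound 3 (0.20 log units; within the scatter). The estimated value for compound 3 in this assay is 2200 nM, within 900 nM to 5000 nM.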

Compound 3, half-maximal effective concentration: 1100 nM
Compound 3: middle estimate off by 2.0-fold (0.30 log units), on the high side; the range from low to high includes it.
By their numbers in this assay, from the lowest: compounds 3 and 1 (each within the scatter of the next); then compound 2.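

In this assay, a fluoro on this ring carries no cost in itself: 3-fluorophenyl in place of phenyl gives (a 1.3-fold lower number from compound 1 to compound 3 (0.10 log units; within the scatter)), so compound 1 and compound 3 cannot be told apart. The placing of the fluoro on the ring does count, since 3-fluorophenyl in place of 2-fluorophenyl gives a modest step (a 3.5-fold lower number from compound 2 to compound 3 (0.55 log units; beyond the scatter)). Among these three compounds, the higher number of compound 2 therefore goes with the 2-fluorophenyl group and not with fluoro on this ring as such.

Open, from the compounds shown here alone, is whether the tolerance seen with 3-fluorophenyl extends to other groups in the same place, such as chloro, methoxy, an amine or a carboxylic acid. Nothing available accounts for the gap between 2-fluorophenyl and 3-fluorophenyl.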